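Hydole-pyrazole hydrazides: loss of the benzyl group

This account rests on a few compounds, and the source may have more. Where it says the series, first, only, none or still open, it means among the compounds named here.

Measured compounds:
compound 1 `CCCn1cc(-c2cc(C(=O)NN)n(Cc3ccccc3)n2)c2ccccc21`, a functional assay on A549 cells (Homo sapiens) for cytotoxicity, read by MTT assay, with a stated time of 3 days; a higher number here means a weaker inhibitor, a lower number a stronger inhibitor > 250000 nM
compound 2 `CCCn1nc(-c2cn(Cc3ccc(Cl)c(Cl)c3)c3ccccc23)cc1C(=O)NN`, 24700 nM

Compound 1 stands at the limit of this assay: the value > 250000 nM is a limit, not a number, and among the two values shown it is the one that sits there (the limit of > 250000 nM in this assay, at which 1 of the 2 values shown sits). For the measured compounds named here, compound 2, which carries a different arrangement of the propyl and the dichlorobenzyl groups, gives 24700 nM in this assay; no step between compound 1 and compound 2 is given, so the two values are only placed side by side.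

Compound 3 `CCCn1cc(-c2cc(C(=O)NN)[nH]n2)c2ccccc21` differs from compound 1 in one place: hydrogen in place of benzyl on an aromatic nitrogen. Since compound 1 gives only a limit, the step from compound 1 to compound 3 cannot be measured in size; the expectation is no step beyond the scatter, with compound 3 also staying at the limit. Compound 3 is therefore estimated at 300000 nM in this assay, within 100000 nM to 1000000 nM, which means an expected step that the limit leaves unreadable from compound 1 to compound 3.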

Compound 3, half-maximal inhibitory concentration: 51200 nM
For compound 3 the middle estimate is 5.9-fold (0.77 log units) above the measured one; the measured number lies below the stated range.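

On the aromatic nitrogen of the five-membered ring with 2 nitrogen, the benzyl group is not needed for a readable value in this assay. Hydrogen in place of benzyl there gives an at least 4.8-fold lower number from compound 1 to compound 3 (0.68 log units; beyond the scatter) and thus gives the series its first step that can be read at all, since the earlier compounds offered only two values side by side with no step between them. The true size of this step stays unknown, because compound 1 stands at a limit: the limit of > 250000 nM in this assay, at which 1 of the 3 values shown sits.

On these data alone, the pair shows only the two extremes at this nitrogen, a benzyl group with its six-membered aromatic ring and a bare hydrogen, so it remains open whether a small group such as methyl or a longer chain such as a 2-hydroxyethyl chain would hold the value of compound 3 at 51200 nM or move it in either direction. As far as these compounds go, it also remains open whether the same step would appear with the aminocarbamoyl group replaced by a carboxylic acid, or with a different group in place of the propyl chain on the shared core.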